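A few compounds are considered here, and "the series" means these few. Any claim that something is new, unique, unknown or untested is made for them only; others in the source may bear on it.

Measured compounds in a functional assay on HT-29 cells (Homo sapiens) for cytotoxicity, read by sulforhodamine B assay, with a stated time of 72 h; a lower number here means a stronger inhibitor, a higher number a weaker inhibitor:

- compound 1, `CCCCC/C=C\C[C@@]1(O)C=C(I)C(=O)/C1=C\C=C\CCCC(=O)OC`, gives > 10000 nM; this is a limit of the assay, not a number.
- compound 2, `CCCCC/C=C\C[C@]1(O)C=CC(=O)/C1=C/C=C\CCCC(=O)OC`, gives 6000 nM.
- compound 3, `CCCCC/C=C\C[C@]1(O)C=CC(=O)/C1=C\C=C\CCCC(=O)OC`, gives 7900 nM.

Compound 1 therefore stands at the edge of what this assay can report, as the limit of > 10000 nM in this assay, at which 1 of the 3 values shown sits, makes plain, while compounds 2 and 3 return numbers inside the measured range. Going by the values given here, the only step between measured compounds is a 1.3-fold higher number from compound 2 to compound 3 (0.12 log units; within the scatter), and it rests on the fact that compounds 2 and 3 differ only in the configuration as drawn: a change of drawn configuration alone, which left the result within the scatter.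

Compound 4, `CCCCC/C=C\C[C@@]1(O)C=C(Br)C(=O)/C1=C\C=C\CCCC(=O)OC`, differs from compound 1 by bromo in place of iodo on a double-bonded ring carbon. Among the compounds with values here, no measured step covers a swap of one halogen for another, so the data give no guide to the direction or size of this change. Because compound 1 offers only > 10000 nM, the starting point itself is uncertain. The step of a number no higher from compound 1 to compound 4 (the limit leaves the size open) is expected to be small and may again end at a limit. Compound 4 is estimated at 10000 nM, within 4000 nM to 30000 nM.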

Compound 4, half-maximal inhibitory concentration: 500 nM
The estimate for compound 4 lay 20-fold (1.30 log units) above the measured number; measured number below the stated range.
By their numbers in this assay, from the lowest: compound 4; then compounds 2 and 3 (each within the scatter of the next). At a limit, above all of these: compound 1.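

On a double-bonded ring carbon of the shared core, the identity of the halogen matters: in this assay the swap of iodo for bromo gives an at least 20-fold lower number from compound 1 to compound 4 (1.30 log units; beyond the scatter) and is the only difference between these two compounds. The earlier step changed only the drawn configuration and stayed within the scatter, whereas this exchange of one heavy atom for another moves the result beyond it. The full size of this step stays open, as compound 1 is reported only as a limit: the limit of > 10000 nM in this assay, at which 1 of the 4 values shown sits.

On these data alone, whether chloro, fluoro or a nitrile in the same place would give a lower or a higher number remains open. Also open, as far as these compounds go, is whether bromo in place of iodo would give a step of similar size with the double bonds of the chain drawn differently.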